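Swapping an Open Amine Chain for a Piperazine Ring

This account rests on a few compounds, and the source may have more. Where it says the series, first, only, none or still open, it means among the compounds named here.

Of the compounds shown here, two have been measured in a functional assay on HCT-116 cells (Homo sapiens) for cytotoxicity, read by sulforhodamine B assay, with stated times of 4 h and 5 days; a lower number here means a stronger inhibitor, a higher number a weaker inhibitor. Compound 1 `O=[N+]([O-])c1nccn1CS(=O)(=O)NCCN1CCCC1` gives 11000 nM. Compound 2 `Cc1ncc([N+](=O)[O-])n1CCS(=O)(=O)NCCN(C)C` gives 800000 nM, the higher of the two numbers, and its gap to compound 1 lies beyond the usual scatter of this kind of measurement. The next compound, compound 3 `Cc1ncc([N+](=O)[O-])n1CCS(=O)(=O)N1CCN(C)CC1`, differs from compound 2 in one place: 4-methylpiperazin-1-yl in place of (2-(dimethylamino)ethyl)amino on a sulfonyl sulfur. Put simply, a 4-methylpiperazin-1-yl replaces a (2-(dimethylamino)ethyl)amino on the sulfonyl sulfur whose other neighbour is a saturated chain carbon. For the measured compounds named here, no measured pair differs in just this way, so nothing here shows which way such a swap moves the number in this assay. The expectation is therefore a step no larger than the usual scatter, in no particular direction. Compound 3 is expected to give about 600000 nM in this assay, within a range from 150000 nM to 2000000 nM. The estimated step of a 1.3-fold lower number from compound 2 to compound 3 (0.12 log units; within the scatter) is expected to stay within the scatter.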

Compound 3, half-maximal inhibitory concentration: 1600000 nM
Compound 3: middle estimate off by 2.7-fold (0.43 log units), on the low side; measured number inside the range.
By their numbers in this assay, from the lowest: compound 1; then compounds 2 and 3 (each within the scatter of the next).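

In this assay, replacing the open (2-(dimethylamino)ethyl)amino with a 4-methylpiperazin-1-yl on the sulfonyl sulfur gives a 2.0-fold higher number from compound 2 to compound 3 (0.30 log units; within the scatter), so the two compounds cannot be told apart in this test. For the compounds shown here, this is the first direct look at this position, and it shows that the swap can add a ring and take away the one hydrogen-bond donor of the leaving group without a change that stands clear of the scatter. No other measurement available here bears on why the two numbers stay this close.

On these data alone, whether another group on the sulfonyl sulfur, such as a morpholine ring or a longer amine chain, would shift the number beyond the scatter remains open. Also open, as far as these compounds go, is whether the same swap would give a similar result on another core, such as that of compound 1.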